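Fluoro Substitution on Two Different Amide Cores

A few compounds are considered here, and "the series" means these few. Any claim that something is new, unique, unknown or untested is made for them only; others in the source may bear on it.

Four compounds are compared here, all tested in a functional assay on EC9706 cells (Homo sapiens) for cytotoxicity, read by MTT assay, with a stated time of 72 h; on this read-out higher numbers stand for weaker inhibition and lower numbers for stronger inhibition. Compound 1, `O=C(CSC(=S)N[C@H]1CCOC1=O)Nc1ccccc1`, carries an unsubstituted phenyl ring on its amide. In this assay compound 1 gives only a limit, > 128000 nM, which means no number was reached; this sits at the limit of > 128000 nM in this assay, at which 1 of the 3 values shown sits. Compound 2, `O=C(CSC(=S)N[C@H]1CCOC1=O)Nc1ccc(F)cc1`, differs from compound 1 by fluoro in place of hydrogen on an aromatic carbon, and in this assay compound 2 gives 67100 nM. The step is an at least 1.9-fold lower number from compound 1 to compound 2 (0.28 log units; that floor lies within the scatter).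

Compound 3, `O=C(CCl)Nc1ccc(C(=O)/C=C/c2ccc(F)cc2)cc1`, is built on a different core, and the difference between the two cores is not broken down here. In this assay compound 3 gives 8600 nM, the lowest number among the measured compounds, and it is well separated from compound 2.

Compound 4, `O=C(CCl)Nc1ccc(C(=O)/C=C/c2ccc(F)c(F)c2)cc1`, has not yet been measured. It differs from compound 3 by fluoro in place of hydrogen on an aromatic carbon. This is the same kind of change as that from compound 1 to compound 2, but not the same: there the fluoro entered para to a large group, here it enters ortho to a fluoro group and meta to a large group. The earlier step from compound 1 to compound 2 was an at least 1.9-fold lower number from compound 1 to compound 2 (0.28 log units; that floor lies within the scatter), a floor that lies within the scatter, so the expected step from compound 3 to compound 4 is small, a 1.2-fold lower number from compound 3 to compound 4 (0.09 log units; within the scatter). Compound 4 is therefore estimated at 7000 nM in this assay, expected between 3000 nM and 17000 nM.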

Compound 4, half-maximal inhibitory concentration: 4630 nM
Estimate against measurement, compound 4: 1.5-fold (0.18 log units) above; the range from low to high includes it.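

On the second core, fluoro in place of hydrogen on an aromatic carbon gives a 1.9-fold lower number from compound 3 to compound 4 (0.27 log units; within the scatter) in this assay. Set beside the earlier step, this shows the same kind of change on two cores with neither step clearing the usual scatter, but it does not show that the change carries over with the same size, and one of the two steps rests on a limit rather than a number: the same change on two cores in this assay, an at least 1.9-fold lower number (0.28 log units; that floor lies within the scatter) from compound 1 to compound 2 and a 1.9-fold lower number (0.27 log units; within the scatter) from compound 3 to compound 4; the limit leaves it open whether they differ In compound 4 the new fluoro also stands ortho to a fluoro group and meta to a large group, which is not the place it takes on the other core, so two such steps are too few to support a rule for this series.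

The compounds shown leave open whether other groups at this place on the ring, such as chloro, methoxy, an amine or a carboxylic acid, would move the read-out further than fluoro does. They also leave open whether a second fluoro set in the same place on the core of compound 2 would give a step of similar size, which would be a closer test of carrying this change across.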